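Para substituent swap on the shared core: chloro to fluoro

A few compounds are considered here, and "the series" means these few. Any claim that something is new, unique, unknown or untested is made for them only; others in the source may bear on it.

Going by the values given here, compound 3 `CC(C)n1nc2c(c1-c1ccc(Cl)cc1)CCNCC2` gives 20 nM in an ADME assay on membranes from Cortex for displacement of a labelled ligand from Adrenergic receptor alpha-1 (Rattus norvegicus), read by radioligand binding, with a stated time of 60 min (a higher number here means a weaker inhibitor, a lower number a stronger inhibitor), the second highest of the three numbers so far. Compound 2 `Cc1ccc(-c2c3c(nn2C(C)C)CCNCC3)cc1` gives 4 nM, and compound 1 `CC(C)n1nc2c(c1-c1ccccc1)CCNCC2`, bearing hydrogen at the same place, gives 530 nM. The step of a 27-fold lower number from compound 1 to compound 3 (1.42 log units; beyond the scatter) is large, as is a 130-fold lower number from compound 1 to compound 2 (2.12 log units; beyond the scatter), while a 5.0-fold higher number from compound 2 to compound 3 (0.70 log units; beyond the scatter) is modest. Compound 4 `CC(C)n1nc2c(c1-c1ccc(F)cc1)CCNCC2` differs from compound 3 by fluoro in place of chloro on an aromatic carbon. Among the compounds with values here, no step involving fluoro at this place has been measured. The two steps from hydrogen show the para substituent matters strongly, so a fluoro is expected to lie between the unsubstituted and chloro cases, with the step of a 7.5-fold higher number from compound 3 to compound 4 (0.88 log units; beyond the scatter) in this assay. The estimate for compound 4 is therefore 150 nM, range 40 nM to 600 nM.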

Compound 4, inhibition constant: 170 nM
Beside the measured number, compound 4's estimate is 1.1-fold (0.05 log units) below it; measured number inside the range.
By their numbers in this assay, from the lowest: compound 2; then compound 3; then compound 4; then compound 1.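

Fluoro at this place, para to a large group, still lowers the number, but only modestly: a 3.1-fold lower number from compound 1 to compound 4 (0.49 log units; beyond the scatter) in this assay. Exchanging one halogen for the other is far from neutral, with an 8.5-fold higher number from compound 3 to compound 4 (0.93 log units; beyond the scatter), and the distance to methyl is wider still, with a 43-fold higher number from compound 2 to compound 4 (1.63 log units; beyond the scatter), which orders this position across the four compounds as methyl, chloro, fluoro, hydrogen. No available evidence accounts for this order.

Open, on these data alone, is where methoxy, trifluoromethyl or an amine at this place would fall in that order.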